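This account rests on a few compounds, and the source may have more. Where it says the series, first, only, none or still open, it means among the compounds named here.

In an ADME assay on CCRF-CEM cells (Homo sapiens) for antiproliferative activity, with a stated time of 48 h (a lower number here means a stronger inhibitor, a higher number a weaker inhibitor), compound 1 `C=C(Br)C(=O)Nc1ccc(/C=C/C(=O)c2ccccc2)cc1` gives 4000 nM, compound 2 `C=C(Br)C(=O)Nc1ccc(/C=C/C(=O)c2ccc(Br)cc2)cc1` gives 990 nM, and compound 3 `Nc1ccc(/C=C/C(=O)c2ccccc2)cc1` gives 34000 nM, the highest number of the three. Compound 4 `Nc1ccc(/C=C/C(=O)c2ccc(I)cc2)cc1` is the next structure to read out. It differs from compound 3 by a single change: iodo in place of hydrogen on an aromatic carbon, para to a large group.

Within the data shown here, two measured steps bear on this. The closer one is a 4.0-fold lower number from compound 1 to compound 2 (0.61 log units; beyond the scatter), where bromo in place of hydrogen on an aromatic carbon lowers the number by a modest amount, beyond the scatter. The other is an 8.5-fold higher number from compound 1 to compound 3 (0.93 log units; beyond the scatter), which shows that compound 3 lacks the (1-bromoethenyl)carbonyl group and sits in a different background from the pair that supplies the bromo step. Among the measured compounds shown here, no iodo compound has been measured yet, and no ring substitution has been measured starting from compound 3. The transfer is therefore uncertain.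

A modest move towards a lower number in this assay is expected, similar in size to the step seen with compound 2 at 990 nM. The expected change is a 4.0-fold lower number from compound 3 to compound 4 (0.60 log units; beyond the scatter). Compound 4 is estimated at 8500 nM, with an expected range of 3000 nM to 25000 nM.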

Compound 4, half-maximal inhibitory concentration: 16000 nM
Estimate against measurement, compound 4: 1.9-fold (0.27 log units) below; the measured number falls inside the stated range.
By their numbers in this assay, from the lowest: compound 2; then compound 1; then compound 4; then compound 3.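

In this assay, among these compounds, the move from hydrogen to iodo, para to a large group, gives a 2.1-fold lower number from compound 3 to compound 4 (0.33 log units; beyond the scatter) and is the first ring substitution read in the background without the (1-bromoethenyl)carbonyl group. Its direction agrees with a 4.0-fold lower number from compound 1 to compound 2 (0.61 log units; beyond the scatter) in the background that carries that group, so both listed halogen pairs move to a lower number and neither goes against this, although each halogen is seen in one background only and the two steps therefore cannot separate the effect of the halogen from that of the background. No measurement at hand accounts for the size or direction of the iodo step.

Open, going by these compounds, is whether iodo and bromo would give matching steps on the same background, which would need the bromo analogue of compound 3 and the iodo analogue of compound 1 to be compared directly with their parents. Also open, on these data alone, is how other groups at this place on the ring, such as chloro, methoxy, trifluoromethyl or a carboxylic acid, would compare with iodo in either background.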